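The source may report more compounds than this note shows. Statements on the series, on what has been measured and on what is new or still open speak of the compounds shown alone.

Compound 1 `COc1ccc(C2=C(c3cc(OC)c(OC)c(OC)c3)C(=O)C(OC(C)=O)C2)cc1F` gave < 1 ug/mL, which is a limit of the assay.
Compound 2 `COCOc1cc(C2=C(c3cc(OC)c(OC)c(OC)c3)C(=O)CC2O[SiH2]C(C)(C)C)ccc1OC` gave 32 ug/mL.
Compound 3 `COc1ccc(C2=C(c3cc(OC)c(OC)c(OC)c3)C(=O)CC2C)cc1C(=O)O` gave > 100 ug/mL, which is a limit of the assay.

In an ADME assay on L132 cells (Homo sapiens) for cytotoxicity, read by MTT assay, with a stated time of 72 h (a lower number here means a stronger inhibitor, a higher number a weaker inhibitor), compound 2 is the only one of the three with a number rather than a limit. Compound 1 sits at the limit of < 1 ug/mL in this assay, at which 1 of the 3 values shown sits. Compound 3 sits at the limit of > 100 ug/mL in this assay, at which 1 of the 3 values shown sits. Compound 4 `COc1ccc(C2=C(c3cc(OC)c(OC)c(OC)c3)C(=O)CC2O[SiH2]C(C)(C)C)cc1O` is not yet measured; it differs from compound 2 in one place: hydrogen in place of methoxymethyl on an oxygen on an aromatic ring. For the measured compounds named here, no measured pair shows a change of this kind, so the size of its effect is unknown. The expected step from compound 2 to compound 4 is a 1.3-fold lower number from compound 2 to compound 4 (0.11 log units; within the scatter), which lies within the usual scatter. Compound 4 is therefore estimated at 25 ug/mL, with a range from 6 ug/mL to 100 ug/mL.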

Compound 4, half-maximal inhibitory concentration: < 1 ug/mL
Compound 4: only a limit was reported; the forecaster's own chance of this, stated with the estimate: 15%; middle value at least 25-fold (1.39 log units) away from the limit.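

In this assay compound 4 gives < 1 ug/mL, which is a limit of the assay: the limit of < 1 ug/mL in this assay, at which 2 of the 4 values shown sit. Replacing the methoxymethyl on this oxygen on the aromatic ring with hydrogen gives an at least 32-fold lower number from compound 2 to compound 4 (1.50 log units; beyond the scatter). For the compounds shown here, this is the first single change seen, and it shows that this oxygen is a place where one small edit moves the number well beyond the scatter.

Going by these compounds, what an ethyl group or a longer chain on this oxygen would give stays open. On these data alone, it is also open whether the free hydroxy itself or simply the loss of methoxymethyl accounts for the step.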